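A Fluorine in Place of a Nitro Group

The compounds below may be only part of what the source reports. "The series", "measured", "known", "first", "only" and "open" are said of these compounds alone.

Compound 3 `O=C(NCc1ccc(CNS(=O)(=O)c2ccc([N+](=O)[O-])cc2)cc1)c1ccc(F)cc1` is measured in an assay on MDA-MB-231 cells for binding affinity to C-X-C chemokine receptor type 4 (Homo sapiens), read by fluorescence and microscopy, with stated times of 10 min and 30 min (a higher number here means that more compound is needed for the effect, a lower number that less compound is needed), at 1000 nM. Compound 2 `O=C(NCc1ccc(CNS(=O)(=O)c2cccnc2)cc1)c1ccc(F)cc1` gives 1000 nM; swapping one small ring for another on the sulfonyl sulfur gave no change at the digits printed from compound 2 to compound 3 (within the scatter), so these two sit together as the highest of the three. Compound 1 `O=C(NCc1ccc(CNS(=O)(=O)c2ccc3c(c2)CCO3)cc1)c1ccc(F)cc1` gives 10 nM, and from it a 100-fold higher number from compound 1 to compound 3 (2.00 log units; beyond the scatter) and a 100-fold higher number from compound 1 to compound 2 (2.00 log units; beyond the scatter). Compound 4 `O=C(NCc1ccc(CNS(=O)(=O)c2ccc(F)cc2)cc1)c1ccc(F)cc1` differs from compound 3 by fluoro in place of nitro on an aromatic carbon. Within the data shown here, no measured step exchanges exactly these two groups. The large steps both involve the larger group of compound 1 and do not bear directly; the closest guide is the exchange between two small rings, which lay within the scatter. A step of a 1.3-fold lower number from compound 3 to compound 4 (0.10 log units; within the scatter) is therefore expected, within the scatter. Compound 4 is estimated at 800 nM, between 250 nM and 3000 nM.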

Compound 4, effective concentration (reported as EC, without a stated level of effect): 1 nM
For compound 4 the middle estimate is 800-fold (2.90 log units) above the measured one; the whole stated range lies above it.
By their numbers in this assay, from the lowest: compound 4; then compound 1; then compounds 2 and 3 (each within the scatter of the next).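

Exchanging nitro for fluoro gives a 1000-fold lower number from compound 3 to compound 4 (3.00 log units; beyond the scatter), so this position responds strongly to the group it carries, although the earlier exchange of 4-nitrophenyl for pyridin-3-yl changed nothing beyond the scatter. The 4-fluorophenyl group also stands apart from the other sulfonyl groups, with a 1000-fold lower number from compound 2 to compound 4 (3.00 log units; beyond the scatter) and a 10-fold lower number from compound 1 to compound 4 (1.00 log units; beyond the scatter), so a second, five-membered ring is not needed for a low number. Nothing available explains the size of these steps. Going by these compounds, it remains open whether this low number is particular to fluoro or would also hold for chloro, methoxy or an amine at the same place.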